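Swapping a ring-bound amine on the shared core

A few compounds are considered here, and "the series" means these few. Any claim that something is new, unique, unknown or untested is made for them only; others in the source may bear on it.

Measured so far:
- compound 1 `CN(c1ccc2cc(NC(=O)CCc3ccc(C(F)(F)F)cc3)ccc2n1)C1CCCCC1`: 1200 nM
- compound 2 `CC1CCCN1c1ccc2cc(NC(=O)CCc3ccc(C(F)(F)F)cc3)ccc2n1`: 270 nM
- compound 3 `CC(C)C(=O)NC1CCN(c2ccc3cc(NC(=O)CCc4ccc(C(F)(F)F)cc4)ccc3n2)C1`: 90 nM

In a functional assay on HEK293 cells for activation of melanin-concentrating hormone receptor 1 (Rattus norvegicus), read by inositol phosphate accumulation (a lower number here means that less compound is needed, a higher number that more compound is needed for the effect), compound 1 has the highest number of the three. Compound 4 `O=C(CCc1ccc(C(F)(F)F)cc1)Nc1ccc2nc(N3CC4CC3CO4)ccc2c1` has not been measured yet; it differs from compound 1 by a group of 7 heavy atoms (5 carbon, 1 nitrogen, 1 oxygen; 2 five-membered non-aromatic rings with 1 hetero atom each) in place of a group of 8 heavy atoms (7 carbon, 1 nitrogen; one six-membered non-aromatic ring of carbon only), on an aromatic carbon, placed next to the ring nitrogen of the core. Going by the values given here, two measured steps bear on this: the step of a 4.4-fold lower number from compound 1 to compound 2 (0.65 log units; beyond the scatter) and the larger step of a 13-fold lower number from compound 1 to compound 3 (1.12 log units; beyond the scatter), both of which replaced the same cyclohexyl(methyl)amino group with a ring-closed amine and lowered the number. Compound 4 carries a ring-closed amine too, so a lower number is expected, beyond the scatter, roughly a 4.0-fold lower number from compound 1 to compound 4 (0.60 log units; beyond the scatter). For compound 4 the estimate is 300 nM, with a range from 100 nM to 900 nM.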

Compound 4, half-maximal effective concentration: 70 nM
Compound 4: middle estimate off by 4.3-fold (0.63 log units), on the high side; measured number below the stated range.
By their numbers in this assay, from the lowest: compounds 4 and 3 (each within the scatter of the next); then compound 2; then compound 1.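

In this assay, the step of a 1.3-fold lower number from compound 3 to compound 4 (0.11 log units; within the scatter) leaves compound 4 and compound 3 indistinguishable, so at this position a group of 7 heavy atoms without the isopropylcarbonyl amide matches the larger group of compound 3. Going by these compounds alone, the step of a 3.9-fold lower number from compound 2 to compound 4 (0.59 log units; beyond the scatter) shows that ring-closed amines here do not all give the same number, and the step of a 17-fold lower number from compound 1 to compound 4 (1.23 log units; beyond the scatter) is large, like the one to compound 3.

On these data alone, whether the oxygen or the second ring matters stays open; a plain morpholine ring or an unsubstituted pyrrolidine could separate the two. No measurement at hand explains these differences.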